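Triazene series: acyl variation at the amide carbonyl

The source may report more compounds than this note shows. Statements on the series, on what has been measured and on what is new or still open speak of the compounds shown alone.

Measured compounds:
Compound 1 `CC(=O)N(/N=N/c1ccc([N+](=O)[O-])cc1Cl)c1ccc([N+](=O)[O-])cc1Cl` gives 630 nM in a functional assay on HeLa cells (Homo sapiens) for cytotoxicity, read by MTT assay, with a stated time of 72 h; a higher number here means a weaker inhibitor, a lower number a stronger inhibitor.
Compound 2 `O=C(c1ccccc1)N(/N=N/c1ccc([N+](=O)[O-])cc1C(F)(F)F)c1ccc([N+](=O)[O-])cc1C(F)(F)F` gives 600 nM in this assay.

Two compounds have been run so far, and their two numbers lie within the scatter of each other; compound 2 therefore sits alongside compound 1 on this assay, with nothing to separate them. The two differ in more than one place, so no single step can be read off between them, and only what the two values show is stated here.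

Compound 3 `CCOC(=O)CC(=O)N(/N=N/c1ccc([N+](=O)[O-])cc1C(F)(F)F)c1ccc([N+](=O)[O-])cc1C(F)(F)F` has not yet been measured in this assay. It departs from compound 2 at one site: (ethoxycarbonyl)methyl in place of phenyl on a carbonyl carbon. The carbonyl carbon carrying the change has an amide-type nitrogen as its other neighbour, so the shared core of compound 2 is left intact.

Within the data shown here, no measured step of this kind exists in the set, so the expectation rests on compound 2 alone. The change from compound 2 to compound 3 is expected to give a step of a 1.3-fold higher number from compound 2 to compound 3 (0.12 log units; within the scatter), that is, no shift beyond the scatter, or at most a small move toward a weaker number. Compound 3 is accordingly estimated at 800 nM, within a range of 350 nM to 2000 nM.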

Compound 3, half-maximal inhibitory concentration: 300 nM
Compound 3: the middle estimate sits 2.7-fold (0.43 log units) above what was measured; measured number outside the range, below it.
By their numbers in this assay, from the lowest: compounds 3, 2 and 1 (each within the scatter of the next, the first and the last beyond it).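

In this assay, among these compounds, (ethoxycarbonyl)methyl in place of phenyl on a carbonyl carbon gives a 2.0-fold lower number from compound 2 to compound 3 (0.30 log units; within the scatter), the first single-site reading. This position therefore takes an open chain with no ring and with hydrogen-bond acceptors in place of a six-membered aromatic ring of carbon only, at the same heavy-atom count, with no shift that can be told from the scatter. Nothing at hand bears on why the two values lie so close, so the result stands without an explanation.

As far as these compounds go, what a carboxylic acid in place of the ethyl ester, a longer chain or an amine on this carbonyl carbon would give remains open. Among the compounds shown here, also open is whether the ring can leave with no shift beyond the scatter when no ethoxycarbonyl group enters with the chain, since the one step read here changes both at once.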